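The source may hold more compounds than are shown below. What is called first, only, known or untested is meant among the compounds shown, and "the series" means these compounds.

Working notes on the series. Three compounds share one core and differ only in the group on a saturated ring carbon of the five-membered ring. Compound 1 `O=C(C(Nc1ccccc1F)c1ccc(C(F)(F)F)cc1)N1CCCC1c1ccccc1F` gives 7 nM in an assay on HEK293 cells for antagonist activity at transient receptor potential M8 protein (Canis lupus familiaris), read by fluorescence and calcium flux, with a stated time of 5 min; a higher number here means a weaker inhibitor, a lower number a stronger inhibitor. Compound 2 `O=C(C(Nc1ccccc1F)c1ccc(C(F)(F)F)cc1)N1CCCC1c1cccc(F)c1` gives 9 nM in this assay, and the step of a 1.3-fold higher number from compound 1 to compound 2 (0.11 log units; within the scatter) does not separate the two. Compound 3 `O=C(C(Nc1ccccc1F)c1ccc(C(F)(F)F)cc1)N1CCCC1c1ccccn1` gives 25 nM in this assay, the highest of the three numbers: the steps of a 3.6-fold higher number from compound 1 to compound 3 (0.55 log units; beyond the scatter) and a 2.8-fold higher number from compound 2 to compound 3 (0.44 log units; beyond the scatter) both lie beyond the scatter, so compound 3 is the weakest inhibitor measured so far.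

Compound 4 `O=C(O)c1cccc(C2CCCN2C(=O)C(Nc2ccccc2F)c2ccc(C(F)(F)F)cc2)c1` is not yet measured. Its change from compound 3 is 3-carboxyphenyl in place of pyridin-2-yl on a saturated ring carbon. Within the data shown here, the steps that bear on it are a 3.6-fold higher number from compound 1 to compound 3 (0.55 log units; beyond the scatter) and a 2.8-fold higher number from compound 2 to compound 3 (0.44 log units; beyond the scatter), which show that an all-carbon six-membered ring at this position gave lower numbers than pyridin-2-yl, while a 1.3-fold higher number from compound 1 to compound 2 (0.11 log units; within the scatter) shows that moving a substituent around that ring changed little. Among the measured compounds shown here, no measured compound carries a carboxy group, so the effect of that part of the change is unknown. A modest decrease or no change beyond the scatter is therefore expected for compound 4, as a 1.7-fold lower number from compound 3 to compound 4 (0.22 log units; within the scatter). The estimate for compound 4 in this assay is 15 nM, with a range from 4 nM to 60 nM.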

Compound 4, half-maximal inhibitory concentration: 40 nM
The estimate for compound 4 lay 2.7-fold (0.43 log units) below the measured number, within the range that was stated.
By their numbers in this assay, from the lowest: compounds 1 and 2 (each within the scatter of the next); then compounds 3 and 4 (each within the scatter of the next).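

At this saturated ring carbon, the all-carbon six-membered ring does not by itself keep the numbers low in this assay: 3-carboxyphenyl and pyridin-2-yl are not separated, at a 1.6-fold higher number from compound 3 to compound 4 (0.20 log units; within the scatter). Substitution on that ring now matters, although the earlier fluoro change did not, at a 1.3-fold higher number from compound 1 to compound 2 (0.11 log units; within the scatter); carboxy in place of fluoro gives a 4.4-fold higher number from compound 2 to compound 4 (0.65 log units; beyond the scatter) and the change from 2-fluorophenyl gives a 5.7-fold higher number from compound 1 to compound 4 (0.76 log units; beyond the scatter), so compound 4 stands apart from both fluorinated compounds without standing apart from compound 3. No measured property of these groups is available to account for these steps.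

Only one carboxy-bearing group is shown, so it remains open whether a carboxylic acid placed elsewhere on the phenyl ring would give the same number as compound 4. Going by these compounds, it also remains open whether a methyl ester, a primary amide or an aminomethyl group in place of the carboxy group would return the numbers to those of compound 1 and compound 2 or stay with those of compound 3 and compound 4.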